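Reversing the enone bridge on a fused pyrazolopyrimidine core

The source may report more compounds than this note shows. Statements on the series, on what has been measured and on what is new or still open speak of the compounds shown alone.

Of the compounds shown here, three that share one core have been measured in a functional assay on DU-145 cells (Homo sapiens) for antiproliferative activity, read by MTT assay, with a stated time of 24 h; on this read-out lower numbers stand for stronger inhibition and higher numbers for weaker inhibition. Compound 1 `COc1ccc(-c2cc(C(=O)/C=C/c3cc(OC)c(OC)c(OC)c3)nc3cc(-c4ccccc4)nn23)cc1OC` gives 14700 nM. Compound 2 `COc1ccc(-c2cc(/C=C/C(=O)c3ccc(Cl)cc3)nc3cc(-c4ccccc4)nn23)cc1OC` gives 21300 nM, and compound 3 `COc1ccc(-c2cc(/C=C/C(=O)c3ccc(C)cc3)nc3cc(-c4ccccc4)nn23)cc1OC` gives 26800 nM. For the measured compounds named here, the only single-point step among them, a 1.3-fold higher number from compound 2 to compound 3 (0.10 log units; within the scatter), concerns methyl in place of chloro on an aromatic carbon and stays within the scatter. Compound 3 carries the highest of the three numbers, yet its gaps to compound 2 and to compound 1 both lie within the scatter, so no ordering can be read from them.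

Compound 4 `COc1ccc(-c2cc(C(=O)/C=C/c3ccccc3)nc3cc(-c4ccccc4)nn23)cc1OC` differs from compound 3 in one place: (2-phenylethenyl)carbonyl in place of 2-((4-methylphenyl)carbonyl)ethenyl on an aromatic carbon. Going by the values given here, compound 1 already carries a (2-phenylethenyl)carbonyl-type arrangement on the core, with a 3,4,5-trimethoxyphenyl at the far end, and its value sits within the scatter of compound 3; no measured step bears directly on the change to compound 4. Compound 4 is therefore expected to show no step beyond the scatter, a 1.6-fold lower number from compound 3 to compound 4 (0.20 log units; within the scatter), with a slight lean toward the value of compound 1. Compound 4 is estimated at 17000 nM, within a range from 6000 nM to 45000 nM.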

Compound 4, half-maximal inhibitory concentration: 15600 nM
Compound 4: the middle estimate sits 1.1-fold (0.04 log units) above what was measured; low and high end bracket the measured number.
By their numbers in this assay, from the lowest: compounds 1, 4, 2 and 3 (each within the scatter of the next).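

For the compounds shown here, compound 4 gives the first direct look at turning the enone bridge around on this aromatic carbon of the shared core, and in this assay the turn barely registers: the data show a 1.7-fold lower number from compound 3 to compound 4 (0.24 log units; within the scatter) and a 1.4-fold lower number from compound 2 to compound 4 (0.14 log units; within the scatter). Neither bridge direction can therefore be told apart from the other here, whichever of the methyl or chloro groups the far phenyl of the ethenyl-first bridge carried. Going by these compounds alone, with the carbonyl-first bridge held in place, the far end can also be read for the first time, and phenyl in place of 3,4,5-trimethoxyphenyl gives a 1.1-fold higher number from compound 1 to compound 4 (0.03 log units; within the scatter), so removing all three methoxy groups leaves the number within the scatter. Nothing available accounts for why these changes leave the read-out so flat.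

The far ring differs along with the bridge direction in both comparisons, so the bridge turn is not isolated from the loss of the chloro or methyl group. Going by these compounds, whether this position responds at all remains open, and a morpholine or a carboxylic acid on the far phenyl, or a saturated two-carbon chain in place of the double bond, would put that to the test.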